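Carbonyl aryl change in a cytotoxicity series

The source may report more compounds than this note shows. Statements on the series, on what has been measured and on what is new or still open speak of the compounds shown alone.

Measured compounds in a functional assay on HepG2 cells (Homo sapiens) for cytotoxicity, read by MTT assay, with a stated time of 48 h; on this read-out higher numbers stand for weaker inhibition and lower numbers for stronger inhibition:
compound 1 : `COc1cc(-c2nnc3n2NC(c2ccco2)C(C(=O)c2cccs2)S3)cc(OC)c1OC`: 64100 nM
compound 2 : `COc1cc(-c2nnc3n2NC(c2cccs2)C(C(=O)c2ccccc2)S3)cc(OC)c1OC`: > 100000 nM (a limit of the assay, not a number)

Within the data shown here, compound 1 carries the only numerical value in this assay. For compound 2 this assay returns only a limit, (the limit of > 100000 nM in this assay, at which 1 of the 2 values shown sits). Among the measured compounds shown here, the two values show both compounds as weak in this assay, and no step between them can be counted.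

Compound 3, `COc1cc(-c2nnc3n2NC(c2ccco2)C(C(=O)c2ccc(C)cc2)S3)cc(OC)c1OC`, differs from compound 1 in one place: 4-methylphenyl in place of thiophen-2-yl on a carbonyl carbon whose other neighbour is a saturated ring carbon. For the measured compounds named here, no measured pair shows the effect of this change, so the step is expected to be small, if any, and not beyond the usual scatter, in either direction. The expected step is a 1.2-fold higher number from compound 1 to compound 3 (0.10 log units; within the scatter). Compound 3 is therefore expected to give about 80000 nM in this assay, within a range from 30000 nM to 200000 nM, with a fair chance that only a limit is reported.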

Compound 3, half-maximal inhibitory concentration: 17400 nM
Compound 3: middle estimate off by 4.6-fold (0.66 log units), on the high side; measured number outside the range, below it.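

In this assay the carbonyl carbon whose other neighbour is a saturated ring carbon proves to be a place where the group matters: 4-methylphenyl in place of thiophen-2-yl gives a 3.7-fold lower number from compound 1 to compound 3 (0.57 log units; beyond the scatter) in this one pair. Among these compounds, this is the first step that can be read, and it lies beyond the usual scatter, so a change at this carbonyl alone can move the number on a shared core. Nothing measured here gives a reason for the step.

As far as these compounds go, whether the step belongs to the six-membered aromatic ring or to its methyl remains open, and a plain phenyl, a 4-chlorophenyl or a pyridin-3-yl on the same carbonyl carbon, with the rest of compound 1 kept, would separate these readings. Compound 2 gives only a limit of the assay and differs from compound 1 and compound 3 in more than one place, so steps to it cannot be read: the limit of > 100000 nM in this assay, at which 1 of the 3 values shown sits.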